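This account rests on a few compounds, and the source may have more. Where it says the series, first, only, none or still open, it means among the compounds named here.

Compound 2 (`CNC(=O)c1cc(C(=O)N[C@H]2[C@@H]3C[C@@H](O)C[C@@H]32)cc2c1OC[C@H]2c1ccccc1`) reads >= 124 ug/mL in a physicochemical assay for solubility (a higher number here means a more soluble compound, a lower number a less soluble compound), and this value is a limit of the assay, not a number. Compound 1 (`CNC(=O)c1cc(C(=O)NC2CC2)cc2c1OC[C@H]2c1cccc2[nH]ccc12`) gives >= 142 ug/mL and this too is only a limit. Compound 3 (`CNC(=O)c1cc(C(=O)N[C@H]2C[C@@H]2C)cc2c1OC[C@@]2(C)c1ccccc1`) gives a true number of 3 ug/mL in this assay and sits far lower. Compound 4 (`CNC(=O)c1cc(C(=O)NC)c2c(c1)[C@H](c1ccccc1)CO2`) carries a methyl where compound 2 has a larger group on an amide-type nitrogen: one carbon atom in place of a group of 7 heavy atoms (6 carbon, 1 oxygen; one three-membered non-aromatic ring of carbon only, one five-membered non-aromatic ring of carbon only), on an amide-type nitrogen. Among the measured compounds shown here, no measured pair shows this change, and the expected step of an at least 1.2-fold lower number from compound 2 to compound 4 (0.09 log units; that floor lies within the scatter) stays within the usual scatter. The range is kept wide because compound 3 gives 3 ug/mL in this assay. For compound 4 the estimate is 100 ug/mL, with an expected range from 30 ug/mL to 200 ug/mL.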

Compound 4, solubility: >= 130 ug/mL
Compound 4: a limit, no number; the forecaster's own chance of this, stated with the estimate: 40%; middle value at least 1.3-fold (0.11 log units) from the limit.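

Among the compounds shown here, compound 2 and compound 4 both read as limits in this assay, not as numbers, so no step between them can be read. On these data alone, whether the methyl of compound 4 or the larger group of compound 2 gives the higher number stays open.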